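Series notes: compound 1 to compound 4 in growth inhibition

The compounds below may be only part of what the source reports. "The series", "measured", "known", "first", "only" and "open" are said of these compounds alone.

Compound 1 `COc1ccc(C(c2ccccc2O)c2cccc3ccccc23)c(OC)c1OC` was run in a functional assay on HCT-116 cells (Homo sapiens) for inhibition, read by sulforhodamine B assay, with a stated time of 48 h (a lower number here means a stronger inhibitor, a higher number a weaker inhibitor), and returned only a limit of the assay, > 20000 nM. Compound 2 `COc1ccc(C(O)(Cc2ccc(F)cc2)c2cccc3ccccc23)c(OC)c1OC` likewise gave in this assay a limit, > 20000 nM. Compound 3 `COc1cc(COC(c2ccc(OC)c(OC)c2OC)c2cccc3ccccc23)cc(OC)c1` also returned in this assay the limit > 20000 nM. Going by the values given here, all values shown sit at one limit (the limit of > 20000 nM in this assay, at which 3 of the 3 values shown sit), so compound 1 stands where every measured compound stands, and no step between measured compounds can be read. Compound 4 `COc1ccc(C(c2ccc(OCC(=O)O)cc2)c2cccc3ccccc23)c(OC)c1OC` differs from compound 1 in one place: 4-(carboxymethoxy)phenyl in place of 2-hydroxyphenyl on a saturated chain carbon bound to two aromatic carbons. Among the compounds with values here, with no measured step to lean on, the expected change in this assay is none beyond the scatter, a step that the limit leaves unreadable from compound 1 to compound 4. Compound 4 is therefore estimated at 30000 nM, within 8000 nM to 100000 nM, most likely reported again as a limit.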

Compound 4, half-maximal inhibitory concentration: 5020 nM
Compound 4: middle estimate off by 6.0-fold (0.78 log units), on the high side, and the stated range ends above it.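

In this assay, the position on the saturated chain carbon bound to two aromatic carbons proves able to carry measurable growth inhibition: 4-(carboxymethoxy)phenyl in place of 2-hydroxyphenyl gives an at least 3.9-fold lower number from compound 1 to compound 4 (0.60 log units; beyond the scatter). Compound 4 alone gives a number rather than a limit, and steps among the other compounds cannot be read: the limit of > 20000 nM in this assay, at which 3 of the 4 values shown sit.

The swap changes the whole group at once, leaving the share of the carboxylic acid, the ether link and the ring placement unseparated. Going by these compounds, whether a methyl ester, an amide or a longer chain would keep this activity remains open.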